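Compound 4 After the Limit of Compound 1

The source may hold more compounds than are shown below. What is called first, only, known or untested is meant among the compounds shown, and "the series" means these compounds.

Measured so far in a functional assay on SK-OV-3 cells (Homo sapiens) for inhibition, read by CCK-8 assay, with a stated time of 70 h (a higher number here means a weaker inhibitor, a lower number a stronger inhibitor), are three compounds:
- Compound 1 `O=C(O)c1cccc(COc2ccc(OCCOCCNC3CCCC3)cc2)c1` gives > 100000 nM as a limit
- Compound 2 `c1ccc(COc2ccc(COc3ccc(OCCOCCNC4CCCCC4)cc3)cc2)cc1` gives 8080 nM as a number
- Compound 3 `O=[N+]([O-])c1ccccc1COc1ccc(OCCOCCNC2CCCCC2)cc1` gives 2880 nM as a number

Compound 1 stands at a limit, > 100000 nM and not at a number. Compound 4 `COC(=O)c1ccc(COc2ccc(OCCOCCNC3CCCC3)cc2)cc1` has 4-(methoxycarbonyl)phenyl in place of 3-carboxyphenyl on a saturated chain carbon bound to an oxygen on an aromatic ring and awaits measurement. Neither compound 2 at 8080 nM nor compound 3 at 2880 nM carries the 3-carboxyphenyl, and both return numbers. An expected step of an at least 12-fold lower number from compound 1 to compound 4 (1.09 log units; beyond the scatter) is estimated toward stronger inhibition, beyond the scatter. For compound 4 the estimated value is 8000 nM with an expected range from 2500 nM to 30000 nM in this assay once it is tested.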

Compound 4, half-maximal inhibitory concentration: 6990 nM
Compound 4: middle estimate off by 1.1-fold (0.06 log units), on the high side; low and high end bracket the measured number.
By their numbers in this assay, from the lowest: compound 3; then compounds 4 and 2 (each within the scatter of the next). At a limit, above all of these: compound 1.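

In this assay, 4-(methoxycarbonyl)phenyl in place of 3-carboxyphenyl on a saturated chain carbon bound to an oxygen on an aromatic ring gives an at least 14-fold lower number from compound 1 to compound 4 (1.15 log units; beyond the scatter). Among the compounds shown here, the earlier compounds differed in more than one place, so this is the first step showing that this place alone can change the read-out. The step's size is bounded on one side only, as compound 1 stands at a limit: the limit of > 100000 nM in this assay, at which 1 of the 4 values shown sits.

The change replaces the carboxylic acid with a methyl ester and also alters the group's substitution, so the compounds shown do not separate the two. Neither 4-carboxyphenyl nor 3-(methoxycarbonyl)phenyl is among them, and either would isolate one change at this place.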